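Notes on a methylsulfanyl replacement across two cores

A few compounds are considered here, and "the series" means these few. Any claim that something is new, unique, unknown or untested is made for them only; others in the source may bear on it.

Measured so far:
compound 1 `O=C(/N=C(/NC(=O)c1cccs1)[Se]Cc1ccccc1)c1cccs1`: > 100000 nM
compound 2 `CS/C(=N\C(=O)c1cccs1)NC(=O)c1cccs1`: > 100000 nM
compound 3 `CS/C(=N\C(=O)c1cnc2ccccc2c1)NC(=O)c1cnc2ccccc2c1`: > 100000 nM

In a functional assay on HT-29 cells (Homo sapiens) for cytotoxicity, read by MTT assay, with a stated time of 72 h (a higher number here means that more compound is tolerated, a lower number that less compound is tolerated), compound 1 gives > 100000 nM, which is a limit of the assay and not a number. Compound 2 likewise gives only a limit in this assay, > 100000 nM. Compound 3 too gives only a limit, > 100000 nM. For the measured compounds named here, the change a group of 8 heavy atoms (7 carbon, 1 selenium; one six-membered aromatic ring of carbon only) in place of a group of 2 heavy atoms (1 carbon, 1 sulfur; no ring), on a carbon with a double bond to nitrogen made a step that the two limits leave unreadable from compound 2 to compound 1; the only evidence on it is the limit of > 100000 nM in this assay, at which 3 of the 3 values shown sit. The difference between the core of compound 2 and the core of compound 3 is not broken down here. Compound 4 `O=C(/N=C(/NC(=O)c1cnc2ccccc2c1)[Se]Cc1ccccc1)c1cnc2ccccc2c1` carries the same change as compound 1, namely (a group of 8 heavy atoms (7 carbon, 1 selenium; one six-membered aromatic ring of carbon only) in place of a group of 2 heavy atoms (1 carbon, 1 sulfur; no ring), on a carbon with a double bond to nitrogen). The step expected from compound 3 to compound 4 in this assay is a number no higher from compound 3 to compound 4 (the limit leaves the size open), resting on compound 1 giving > 100000 nM after the same change. Compound 4 is therefore estimated at 100000 nM, most likely again only a limit.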

Compound 4, concentration lethal to 50% of the cells: > 100000 nM
Compound 4: only a limit was reported; the forecaster's own chance of this, stated with the estimate: 75%; the middle value lies on the limit itself.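

No step can be read from compound 3 to compound 4: both values are limits, not numbers. The compounds shown leave open whether replacing methylsulfanyl shifts cytotoxicity at all on either core, with none of them giving a number.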